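The compounds below may be only part of what the source reports. "The series", "measured", "known", "first", "only" and "open" are said of these compounds alone.

Working notes on the series in a functional assay on MDA-MB-231 cells (Homo sapiens) for antiproliferative activity, read by MTT assay, with a stated time of 72 h; a higher number here means a weaker inhibitor, a lower number a stronger inhibitor: compound 1 `O=C(NO)c1ccc(NCCOc2ccc3cc2COC/C=C/COCc2cccc(c2)-c2ccnc(n2)N3)cc1` gives 8690 nM, compound 2 `O=C(O)c1ccc(OCCOc2ccc3cc2COC/C=C/COCc2cccc(c2)-c2ccnc(n2)N3)cc1` gives 54200 nM, and compound 3 `O=C(O)CCCCCOc1ccc2cc1COC/C=C/COCc1cccc(c1)-c1ccnc(n1)N2` gives 19900 nM, the middle of the three numbers. Compound 4 `O=C(O)c1cccc(NCCOc2ccc3cc2COC/C=C/COCc2cccc(c2)-c2ccnc(n2)N3)c1` is still unmeasured. The change from compound 3 is (3-carboxyphenyl)amino in place of 3-carboxypropyl on a saturated chain carbon, two bonds along the chain from an oxygen on an aromatic ring. Within the data shown here, no measured step matches this exactly. The closest are a 2.7-fold lower number from compound 2 to compound 3 (0.44 log units; beyond the scatter) and a 2.3-fold higher number from compound 1 to compound 3 (0.36 log units; beyond the scatter), both modest. A small move toward a higher number in this assay is expected, possibly not beyond the scatter. The expected step is a 1.5-fold higher number from compound 3 to compound 4 (0.18 log units; within the scatter). The estimate for compound 4 is 30000 nM, with a range of 12000 nM to 70000 nM.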

Compound 4, half-maximal inhibitory concentration: 21400 nM
Compound 4: the middle estimate sits 1.4-fold (0.15 log units) above what was measured; measured number inside the range.
By their numbers in this assay, from the lowest: compound 1; then compounds 3 and 4 (each within the scatter of the next); then compound 2.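

In this assay, (3-carboxyphenyl)amino in place of 3-carboxypropyl gives a 1.1-fold higher number from compound 3 to compound 4 (0.03 log units; within the scatter), so at this place on the chain an aromatic ring and an amine nitrogen enter with no step beyond the scatter. The same group in place of 4-carboxyphenoxy gives a 2.5-fold lower number from compound 2 to compound 4 (0.40 log units; beyond the scatter), while on the amine nitrogen, 3-carboxyphenyl in place of 4-(hydroxycarbamoyl)phenyl gives a 2.5-fold higher number from compound 1 to compound 4 (0.39 log units; beyond the scatter). No evidence on hand explains these steps.

Still open, going by these compounds, is how 4-carboxyphenyl on the amine nitrogen would read, which would separate the place of the carboxylic acid from the exchange of hydroxycarbamoyl for it. A simple primary amine at this place is also untested among the compounds shown.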